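This account rests on a few compounds, and the source may have more. Where it says the series, first, only, none or still open, it means among the compounds named here.

Compound 3 `CCCCCCCCCCCCCCNC(=O)[C@@H](NC(=O)c1cc2ccccc2[nH]1)[C@@H](C)O` is the reference point here. In a functional assay on A-431 cells (Homo sapiens) for cytotoxicity, read by MTT assay, with a stated time of 48 h (on this read-out higher numbers stand for weaker inhibition and lower numbers for stronger inhibition), compound 3 gives 12300 nM, the smallest of the three numbers recorded, although the gap to compound 1 is within the scatter. Compound 1 `CCCCCCCCCCCCCCNC(=O)[C@@H](N)[C@@H](C)O` carries a plain hydrogen on the amine nitrogen where compound 3 carries the indolylcarbonyl group; in this assay compound 1 gives 14600 nM. The step of a 1.2-fold lower number from compound 1 to compound 3 (0.07 log units; within the scatter) is within the scatter. Compound 2 `CCCCCCCCCCCCCCNC(=O)[C@@H](NC(=O)c1cccs1)[C@@H](C)O`, with a thiophenylcarbonyl group in that position, gives 26500 nM. The step of a 1.8-fold higher number from compound 1 to compound 2 (0.26 log units; within the scatter) is within the scatter, and the step of a 2.2-fold lower number from compound 2 to compound 3 (0.33 log units; beyond the scatter) is modest but beyond it.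

Compound 4 `C/C=C/C=C/C(=O)N[C@H](C(=O)NCCCCCCCCCCCCCC)[C@@H](C)O` differs from compound 3 by penta-1,3-dien-1-yl in place of 1H-indol-2-yl on a carbonyl carbon. The steps that bear on this change are the ones in which the group on that carbonyl carbon was swapped or removed altogether: neither the removal nor the thiophene-to-indole exchange moved the number by more than a modest amount, so the carbonyl substituent appears to matter little among these compounds. For compound 4 the expected step of a 1.3-fold higher number from compound 3 to compound 4 (0.11 log units; within the scatter) is therefore small, with no clear direction beyond the scatter. The estimate for compound 4 in this assay is 16000 nM, expected to fall between 6000 nM and 45000 nM.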

Compound 4, half-maximal inhibitory concentration: > 200000 nM
Compound 4: only a limit was reported (the forecaster's own chance of this, stated with the estimate: 10%); middle value at least 12-fold (1.09 log units) away from the limit.
By their numbers in this assay, from the lowest: compounds 3, 1 and 2 (each within the scatter of the next, the first and the last beyond it). At a limit, above all of these: compound 4.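

Compound 4 gives only a limit, not a true number, in this assay: the limit of > 200000 nM in this assay, at which 1 of the 4 values shown sits. Even so, the group on this carbonyl carbon clearly does matter, as replacing the ring-bearing groups with the open-chain penta-1,3-dien-1-yl gives an at least 16-fold higher number from compound 3 to compound 4 (1.21 log units; beyond the scatter) and an at least 7.5-fold higher number from compound 2 to compound 4 (0.87 log units; beyond the scatter). Compared with the plain amine, the same change gives an at least 13-fold higher number from compound 1 to compound 4 (1.13 log units; beyond the scatter), whereas compound 2 and compound 3, whose groups contain aromatic rings, each stay within the scatter of compound 1, so adding a carbonyl group to that nitrogen does not by itself produce the large step.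

With only one open-chain group shown, it remains open whether this step goes with the missing aromatic ring, the two double bonds or the smaller group, and the limit leaves its true size unknown. A saturated pentyl chain or a phenyl ring on the same carbonyl carbon would help to separate these possibilities.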